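Changing the five-membered ring on the side chain

The source may report more compounds than this note shows. Statements on the series, on what has been measured and on what is new or still open speak of the compounds shown alone.

Compound 3, `Cc1ccc2c(c1)C=C(CC1CN=CN1)CC2`, is the reference point. Going by the values given here, in a functional assay for binding affinity to Norepinephrine transporter (Rattus norvegicus), read by radioligand binding, in the presence of a further agent that is not named here (a higher number here means a weaker inhibitor, a lower number a stronger inhibitor), compound 3 gives 1000 nM, the only plain number among the three measured compounds. Compound 1, `FC(F)(F)c1ccc2c(c1)C=C(CC1CN=CN1)CC2`, gives in this assay < 10000 nM, which is a limit of the assay rather than a number. Compound 2, `COc1ccc2c(c1)C=C(CC1CN=CN1)CC2`, gives in this assay < 1000 nM, again a limit. The steps a step that the two limits leave unreadable from compound 1 to compound 2, a step that the limit leaves unreadable from compound 1 to compound 3 and a number no lower from compound 2 to compound 3 (the limit leaves the size open) all concern the substituent on the aromatic carbon and are left unreadable by the limit of < 1000 nM in this assay, at which 1 of the 3 values shown sits, and (the limit of < 10000 nM in this assay, at which 1 of the 3 values shown sits). Compound 4, `Cc1ccc2c(c1)C=C(CC1CN=C(N)O1)CC2`, differs from compound 3 by a group of 6 heavy atoms (3 carbon, 2 nitrogen, 1 oxygen; one five-membered non-aromatic ring with 2 hetero atoms) in place of a group of 5 heavy atoms (3 carbon, 2 nitrogen; one five-membered non-aromatic ring with 2 hetero atoms), on a saturated chain carbon bound to a double-bonded ring carbon. Among the compounds with values here, no measured step touches this part of the molecule, so the expectation rests on compound 3 alone, with wide uncertainty. Compound 4 is expected to give 1500 nM, between 400 nM and 6000 nM. The expected step is a 1.5-fold higher number from compound 3 to compound 4 (0.18 log units; within the scatter), not clearly beyond the usual scatter.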

Compound 4, inhibition constant: < 1000 nM
Compound 4 gave a limit, no number (the forecaster's own chance of this, stated with the estimate: 20%); at least 1.5-fold (0.17 log units) between middle value and limit.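

The change of ring at the saturated chain carbon bound to a double-bonded ring carbon is the first change shown at this place, and in this assay it brings no loss: the result is a number no higher from compound 3 to compound 4 (the limit leaves the size open). The result for compound 4 is a limit of the assay, not a number. The size of the step cannot be read because of that limit: the limit of < 1000 nM in this assay, at which 2 of the 4 values shown sit.

The compounds shown leave open how far compound 4 lies from compound 3. They also leave open whether the new ring behaves alike with methoxy or trifluoromethyl on the aromatic carbon, and what a carboxylic acid in place of that ring would give.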